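The source may report more compounds than this note shows. Statements on the series, on what has been measured and on what is new or still open speak of the compounds shown alone.

Of the compounds shown here, three that share one core have been read in a functional assay on U-937 cells (Homo sapiens) for cytotoxicity, read by MTT assay, with a stated time of 24 h; a higher number here means a weaker inhibitor, a lower number a stronger inhibitor. In this test compound 1 (`CC(C)(C)OC(=O)N1CCCN(CCCCCOc2c(Br)cc(Br)cc2Oc2ccc(Br)cc2Br)CC1`) gives 39.5 ug/mL. Compound 2 (`OCCCOc1c(Br)cc(Br)cc1Oc1ccc(Br)cc1Br`) gives 32.3 ug/mL, and compound 3 (`COc1ccccc1N1CCN(CCCCCOc2c(Br)cc(Br)cc2Oc2ccc(Br)cc2Br)CC1`) gives 37.5 ug/mL. Compound 2 therefore stands within the scatter of both other compounds, and the three numbers cannot be ranked, although the groups carried on the shared core differ considerably.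

The next compound to be read is compound 4 (`CC(C)(C)C(=O)C(C#N)Oc1c(Br)cc(Br)cc1Oc1ccc(Br)cc1Br`). It has cyano((tert-butyl)carbonyl)methyl in place of 3-hydroxypropyl on an oxygen on an aromatic ring, the change from compound 2 being (cyano((tert-butyl)carbonyl)methyl in place of 3-hydroxypropyl on an oxygen on an aromatic ring). Among the measured compounds shown here, no measured pair in the set isolates a single change, so there is no direct step to serve as a guide. The only support is the closeness of the three numbers, with compound 1 at 39.5 ug/mL and compound 3 at 37.5 ug/mL both lying within the scatter of compound 2. No step beyond the scatter is therefore expected in this assay, and no direction can be assigned with confidence. The estimated step is a 1.1-fold lower number from compound 2 to compound 4 (0.03 log units; within the scatter). For compound 4 the expected value is 30 ug/mL, with an estimated range from 14 ug/mL to 60 ug/mL.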

Compound 4, half-maximal inhibitory concentration: 32.5 ug/mL
The estimate for compound 4 lay 1.1-fold (0.03 log units) below the measured number; the measured number falls inside the stated range.
By their numbers in this assay, from the lowest: compounds 2, 4, 3 and 1 (each within the scatter of the next).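

In this assay, among the compounds shown here, putting cyano((tert-butyl)carbonyl)methyl in place of 3-hydroxypropyl on an oxygen on an aromatic ring gives a 1.0-fold higher number from compound 2 to compound 4 (0.00 log units; within the scatter), the first single change in this set that can be read directly. The exchange is a large one: 9 heavy atoms enter where 4 leave, a nitrile and a carbonyl arrive, and the hydroxyl goes, taking the number of hydrogen-bond donors in the group from 1 to 0, yet the step stays within the scatter, so at this position the hydroxyl is not needed for the number to hold. No measurement is available that accounts for this result.

On these data alone, whether an amine or a carboxylic acid on this oxygen would give a step beyond the scatter remains open, as does the effect of a small group such as methyl. Also open is whether putting chlorine or hydrogen in place of bromine on the shared core would move the number, as all the compounds shown carry the same bromines.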